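Dienone aryl ethers: a gastric cancer cell growth series

The source may hold more compounds than are shown below. What is called first, only, known or untested is meant among the compounds shown, and "the series" means these compounds.

In a functional assay on MGC-803 cells (Homo sapiens) for inhibition, read by MTT assay, with a stated time of 72 h, tested at 10 uM (a lower number here means less inhibition of growth, a higher number more inhibition of growth at the concentration tested), the measured compounds stand as follows:
compound 1 `O=C(/C=C/c1ccc(Oc2ncnc3ccc(Cl)cc23)cc1)/C=C/c1c(Cl)cccc1Cl`: 61.7%
compound 2 `O=C(/C=C/c1ccc(Oc2ncnc3ccc(Cl)cc23)cc1)/C=C/c1ccc(Cl)c([N+](=O)[O-])c1`: 66.2%
compound 3 `O=C(/C=C/c1ccc(Cl)c(Cl)c1)/C=C/c1ccccc1Oc1ncnc2ccc(Cl)cc12`: 56.7%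

Compound 2 holds the highest of the three numbers, yet its gaps to compound 1 and to compound 3 both lie within the scatter, so no order among them can be claimed. Compound 4 `O=C(/C=C/c1ccc(Oc2ncnc3ccc(Cl)cc23)cc1)/C=C/c1cccc(Cl)c1Cl` has not yet been measured; it differs from compound 2 by 2,3-dichlorophenyl in place of 4-chloro-3-nitrophenyl on a double-bonded chain carbon bound to a double-bonded chain carbon. For the measured compounds named here, the only measured step that bears on this change is a number 4.5 percentage points higher from compound 1 to compound 2 (within the scatter), where a different dichlorophenyl was exchanged for the same nitro-bearing ring. On that basis no step beyond the scatter is expected, a number 4.2 percentage points lower from compound 2 to compound 4 (within the scatter). Compound 4 is therefore estimated at 62%, with a range from 50% to 74%.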

Compound 4, percent growth inhibition at one concentration: 68.5%
Estimate against measurement, compound 4: 6.5 percentage points below, within the range that was stated.
By their numbers in this assay, from the lowest: compounds 3, 1, 2 and 4 (each within the scatter of the next, the first and the last beyond it).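

In this assay, 2,3-dichlorophenyl on a double-bonded chain carbon bound to a double-bonded chain carbon gives, in place of 4-chloro-3-nitrophenyl, a number 2.3 percentage points higher from compound 2 to compound 4 (within the scatter) and, in place of 2,6-dichlorophenyl, a number 6.8 percentage points higher from compound 1 to compound 4 (within the scatter) at this same place. Three aryl groups at this place, two dichlorophenyl groups and one bearing a nitro group, now cannot be told apart in this assay. Nothing available explains this result. As far as these compounds go, what an amine, a carboxylic acid or a longer chain would give at this place remains open. So does whether any group there would stand beyond the scatter of these three.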